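A few compounds are considered here, and "the series" means these few. Any claim that something is new, unique, unknown or untested is made for them only; others in the source may bear on it.

Of the compounds shown here, three have been measured in a physicochemical assay for lipophilicity, read by HPLC, in phosphate buffer, measured as chromatographic lipophilicity, at pH 7.4; a higher number here means a more lipophilic compound, a lower number a more polar compound. Compound 1 `Cc1cc(C)cc(NC(=O)COc2cc(C)nc3ccccc23)c1` gives 5.39, and compound 2 `COc1ccc2nc(C)cc(OCc3ccc4ccccc4n3)c2c1` gives 5.48, two numbers that lie within the scatter of each other. Compound 3 `COc1ccc(NC(=O)COc2cc(C)nc3ccc(OC)cc23)cc1` gives 4.22, the lowest of the three, with compound 1 and compound 2 both well beyond the scatter above it.

Compound 4 `COc1ccc2nc(C)cc(OCC(=O)Nc3ccncc3)c2c1` has not yet been measured in this assay. It differs from compound 3 in one place: pyridin-4-yl in place of 4-methoxyphenyl on an amide-type nitrogen. A smaller ring with a nitrogen atom replaces the 4-methoxyphenyl group on the amide-type nitrogen. Within the data shown here, no measured pair here shows this exact change, so the direction can only be reasoned from the change itself.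

Compound 4 is expected to come out lower than compound 3, with a step from compound 3 to compound 4 of about a number 1.32 log units lower from compound 3 to compound 4 (beyond the scatter), a clear drop beyond the scatter. On that basis compound 4 is estimated at 2.9, most likely between 2.3 and 3.5.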

Compound 4, distribution coefficient: 2.5
Compound 4: the middle estimate sits 0.40 log units above what was measured; low and high end bracket the measured number.
By their numbers in this assay, from the lowest: compound 4; then compound 3; then compounds 1 and 2 (each within the scatter of the next).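

In this assay, among these compounds, putting pyridin-4-yl in place of 4-methoxyphenyl on the amide-type nitrogen gives a number 1.72 log units lower from compound 3 to compound 4 (beyond the scatter), the first step in this set where only one place differs. It shows that the group on this nitrogen can, on its own, shift the reading by a large amount while the rest of the molecule stays the same, and compound 4, at 2.5, now has the lowest number of the four. Nothing measured here explains the size of this drop.

This single step swaps the ring and removes the methoxy group together, so the share of each in the drop remains unresolved. A plain phenyl on the same nitrogen would separate the two, and pyridin-3-yl would show whether the placing of the ring nitrogen matters.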